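The source may report more compounds than this note shows. Statements on the series, on what has been measured and on what is new or still open speak of the compounds shown alone.

Compound 1 `CN1CCN(CCNCc2cn(-c3ccc(F)cc3F)nc2Cc2ccccc2)CC1`: > 20000 nM
Compound 2 `CN1CCN(CCNCc2cn(-c3ccc([N+](=O)[O-])cc3)nc2-c2ccc(OC(F)(F)F)cc2)CC1`: 4400 nM
Compound 3 `Cc1ccccc1-c1nn(C(C)C)cc1CNCCN1CCN(C)CC1`: > 20000 nM

In an ADME assay on Huh-7 cells (Homo sapiens) for cytotoxicity (on this read-out higher numbers stand for lower toxicity in this test and lower numbers for higher toxicity in this test), compound 3 gives only a limit of the assay, > 20000 nM, not a number. Compound 1 also gives only a limit, > 20000 nM. Compound 2 gives a number, 4400 nM. Two of three values thus sit at the limit of > 20000 nM in this assay, at which 2 of the 3 values shown sit, and compound 3 cannot be placed more closely than that.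

Compound 4 `Cc1ccc(-n2cc(CNCCN3CCN(C)CC3)c(-c3ccccc3C)n2)c(C)c1` differs from compound 3 by 2,4-dimethylphenyl in place of isopropyl on an aromatic nitrogen, in words: 2,4-dimethylphenyl in place of isopropyl on an aromatic nitrogen. For the measured compounds named here, no measured pair covers this change. Compound 1 also bears an aromatic ring on the aromatic nitrogen of the shared core and still reports a limit, so the change is expected to bring no step beyond the scatter, a number no higher from compound 3 to compound 4 (the limit leaves the size open). Compound 4 is therefore expected near 20000 nM, with a range of 6000 nM to 60000 nM.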

Compound 4, half-maximal cytotoxic concentration: > 20000 nM
Compound 4: no number, only a limit; the forecaster's own chance of this, stated with the estimate: 60%; the middle value sits exactly at the limit.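

Compound 3 and compound 4 both report only a limit in this assay, so the step between them cannot be read. Whether 2,4-dimethylphenyl in place of isopropyl on an aromatic nitrogen changes this read-out at all stays open: the limit of > 20000 nM in this assay, at which 3 of the 4 values shown sit.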